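Urea-linked anilinoquinazolines: replacing the anilino aryl group

The source may hold more compounds than are shown below. What is called first, only, known or untested is meant among the compounds shown, and "the series" means these compounds.

Measured so far:
compound 1, `CN1CCN(Cc2ccc(NC(=O)Nc3ccc4ncnc(Nc5ccc(F)c(F)c5)c4c3)cc2)CC1`; in a functional assay on A-431 cells (Homo sapiens) for antiproliferative activity, read by MTT assay, with a stated time of 72 h (a higher number here means a weaker inhibitor, a lower number a stronger inhibitor), compound 1 gives > 10000 nM
compound 2, `CCN(CC)Cc1ccc(NC(=O)Nc2ccc3ncnc(Nc4cccc(C(F)(F)F)c4)c3c2)cc1`; in this assay compound 2 gives 3980 nM

Compound 1 stands at the edge of what this assay reports: its value is a limit, not a number (the limit of > 10000 nM in this assay, at which 1 of the 2 values shown sits). Compound 2 returns a number. Among the compounds with values here, the two compounds differ in more than one place, so no single step between them is defined, and the pair shows only a limit beside a number.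

Compound 3, `C[C@@H](Nc1ncnc2ccc(NC(=O)Nc3ccc(CN4CCN(C)CC4)cc3)cc12)c1ccccc1`, is not yet measured. It differs from compound 1 by 1-phenylethyl in place of 3,4-difluorophenyl on a nitrogen on an aromatic ring. Within the data shown here, no measured step of this kind exists, so the direction of the change is not fixed by the data; the expected step of an at least 1.2-fold lower number from compound 1 to compound 3 (0.09 log units; that floor lies within the scatter) is therefore set near none beyond the scatter, with a wide range on either side. Compound 3 is expected to give about 8000 nM in this assay, estimated between 1500 nM and 40000 nM, with a real chance that only a limit is reported again.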

Compound 3, half-maximal inhibitory concentration: > 10000 nM
Compound 3: a limit, no number; the forecaster's own chance of this, stated with the estimate: 45%; at least 1.2-fold (0.09 log units) between middle value and limit.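

In this assay compound 3 gives > 10000 nM as a limit, not a number. Compound 1 also stands at a limit, so no step from compound 1 to compound 3 can be read: the limit of > 10000 nM in this assay, at which 2 of the 3 values shown sit.

The compounds shown leave open whether 1-phenylethyl in place of 3,4-difluorophenyl on a nitrogen on an aromatic ring moves the value in either direction, and by how much.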